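Aryl Swap on the Ring Nitrogen

The source may report more compounds than this note shows. Statements on the series, on what has been measured and on what is new or still open speak of the compounds shown alone.

Compound 2 `Cc1ccc(N2CCN(C(=S)SCc3ccc4nc(N)nc(N)c4c3)CC2)cc1` gives 5510 nM in a functional assay on HCT-116 cells (Homo sapiens) for antiproliferative activity, read by MTT assay, with a stated time of 72 h; a lower number here means a stronger inhibitor, a higher number a weaker inhibitor. Compound 1 `Nc1nc(N)c2cc(CSC(=S)N3CCN(c4ccc(O)cc4)CC3)ccc2n1` gives 5980 nM, and the two numbers lie within the scatter of each other, so neither stands apart. Among the measured compounds shown here, the only measured step, a 1.1-fold lower number from compound 1 to compound 2 (0.04 log units; within the scatter), alters the same aryl group that changes here. Compound 3 `Nc1nc(N)c2cc(CSC(=S)N3CCN(c4ccccc4Cl)CC3)ccc2n1` differs from compound 2 by 2-chlorophenyl in place of 4-methylphenyl on an amine nitrogen in a ring. For the measured compounds named here, with that single step as the sole guide, no step beyond the scatter is expected in this assay, and the estimated step of a 1.0-fold lower number from compound 2 to compound 3 (0.00 log units; within the scatter) reflects this. Compound 3 is therefore expected near 5500 nM, within 2500 nM to 12000 nM.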

Compound 3, half-maximal inhibitory concentration: 5490 nM
The estimate for compound 3 lay 1.0-fold (0.00 log units) above the measured number, and the stated range covers the measured number.
By their numbers in this assay, from the lowest: compounds 3, 2 and 1 (each within the scatter of the next).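

The 2-chlorophenyl group on the amine nitrogen in the ring reads level with both earlier aryl groups in this assay: a 1.0-fold lower number from compound 2 to compound 3 (0.00 log units; within the scatter), and a 1.1-fold lower number from compound 1 to compound 3 (0.04 log units; within the scatter). Compound 1 and compound 2 carried only 4-substituted phenyl groups, whereas compound 3 extends this flat reading to a chlorine-bearing 2-substituted phenyl group. No measurement given here accounts for this agreement.

From the compounds shown here alone, whether the number holds with something other than a substituted phenyl group on that nitrogen, such as a benzyl group or a pyridyl ring, remains open.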